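Benzyl carbamate in a phenyl selenocyanate series

The source may hold more compounds than are shown below. What is called first, only, known or untested is meant among the compounds shown, and "the series" means these compounds.

Measured in a functional assay on HT-29 cells (Homo sapiens) for cytotoxicity, read by MTT assay, with a stated time of 72 h; on this read-out higher numbers stand for weaker inhibition of growth and lower numbers for stronger inhibition of growth:
Compound 1, `CCCCOC(=O)Nc1ccc([Se]C#N)cc1`, gives 31300 nM.
Compound 2, `C=CCOC(=O)Nc1ccc([Se]C#N)cc1`, gives 48600 nM.
Compound 3, `CCCCCCOC(=O)Nc1ccc([Se]C#N)cc1`, gives 40300 nM.

Compound 3 sits in the middle of this small set, but not apart from it: the step of a 1.3-fold higher number from compound 1 to compound 3 (0.11 log units; within the scatter) and the step of a 1.2-fold lower number from compound 2 to compound 3 (0.08 log units; within the scatter) are both within the scatter, as is a 1.6-fold higher number from compound 1 to compound 2 (0.19 log units; within the scatter). Nothing among the three measured numbers separates the propyl, vinyl and pentyl chains.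

Compound 4, `N#C[Se]c1ccc(NC(=O)OCc2ccccc2)cc1`, differs from compound 3 by phenyl in place of pentyl on a saturated chain carbon bound to an oxygen next to a carbonyl group. Among the measured compounds shown here, no measured step exchanges a chain for a ring, so none bears on it directly; the two steps that touch the same place, from compound 1 to compound 2 and from compound 2 to compound 3, were each within the scatter. On that basis compound 4 is expected to show no step beyond the scatter in this assay, a change of about a 1.0-fold lower number from compound 3 to compound 4 (0.00 log units; within the scatter). Compound 4 is therefore estimated at 40000 nM, within a range from 15000 nM to 100000 nM.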

Compound 4, concentration for total growth inhibition: 41200 nM
Estimate against measurement, compound 4: 1.0-fold (0.01 log units) below; the measured number falls inside the stated range.
By their numbers in this assay, from the lowest: compounds 1, 3, 4 and 2 (each within the scatter of the next).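

In this assay, the saturated chain carbon bound to an oxygen next to a carbonyl group now carries an aromatic ring as well as open chains, and the change to phenyl gives no separation from any of them: a 1.0-fold higher number from compound 3 to compound 4 (0.01 log units; within the scatter), a 1.2-fold lower number from compound 2 to compound 4 (0.07 log units; within the scatter) and a 1.3-fold higher number from compound 1 to compound 4 (0.12 log units; within the scatter). Among the compounds shown here, earlier steps had compared only chains, so this is the first sign that exchanging a chain for one six-membered aromatic ring of carbon only leaves the number within the scatter. No supporting evidence bears on why this is so.

The compounds shown leave open whether a cyclohexyl ring, a phenyl ring bearing a chloro or methoxy group, or a longer chain would move the number beyond the scatter. The same holds for an amine or a carboxylic acid in this place.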